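A few compounds are considered here, and "the series" means these few. Any claim that something is new, unique, unknown or untested is made for them only; others in the source may bear on it.

Measured so far in an ADME assay on MT4 cells (Homo sapiens) for cytotoxicity, read by MTT assay, with a stated time of 4 days; a lower number here means that less compound is tolerated, a higher number that more compound is tolerated:
compound 1 `Cc1cc(-c2cccc(C#N)c2)cc(C)c1Nc1ccnc(Nc2ccc(C#N)cc2)n1` gives 920 nM;
compound 2 `Cc1cc(-c2ccccc2C(F)(F)F)cc(C)c1Nc1ccnc(Nc2ccc(C#N)cc2)n1` gives 4210 nM;
compound 3 `Cc1cc(-c2cccc(Cl)c2)cc(C)c1Nc1ccnc(Nc2ccc(C#N)cc2)n1` gives 2160 nM.

Compound 3 stands second highest of the three numbers in this assay; its nearest neighbour is compound 2 a 1.9-fold lower number from compound 2 to compound 3 (0.29 log units; within the scatter), its furthest is compound 1 a 2.3-fold higher number from compound 1 to compound 3 (0.37 log units; beyond the scatter). Compound 4 `Cc1cc(C)cc(-c2cc(C)c(Nc3ccnc(Nc4ccc(C#N)cc4)n3)c(C)c2)c1` differs from compound 3 by 3,5-dimethylphenyl in place of 3-chlorophenyl on an aromatic carbon. Going by the values given here, no measured step swaps exactly these two groups. Among the compounds with values here, the steps that bear on it are a 2.3-fold higher number from compound 1 to compound 3 (0.37 log units; beyond the scatter) and a 4.6-fold higher number from compound 1 to compound 2 (0.66 log units; beyond the scatter), both modest, and a 1.9-fold lower number from compound 2 to compound 3 (0.29 log units; within the scatter). A change of the same order, toward a higher number in this assay, is therefore expected for compound 4, estimated as a 1.4-fold higher number from compound 3 to compound 4 (0.14 log units; within the scatter), giving an expected value of 3000 nM with a range from 1200 nM to 7500 nM.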

Compound 4, half-maximal cytotoxic concentration: 4140 nM
Estimate against measurement, compound 4: 1.4-fold (0.14 log units) below; the range from low to high includes it.
By their numbers in this assay, from the lowest: compound 1; then compounds 3, 4 and 2 (each within the scatter of the next).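

In this assay, the 3,5-dimethylphenyl group of compound 4 shows that a ring bearing only methyl groups at this position joins the chloro and trifluoromethyl cases: a 1.9-fold higher number from compound 3 to compound 4 (0.28 log units; within the scatter) and a 1.0-fold lower number from compound 2 to compound 4 (0.01 log units; within the scatter) both stay within the scatter. Only the 3-cyanophenyl group stands apart, with a 4.5-fold higher number from compound 1 to compound 4 (0.65 log units; beyond the scatter) beyond it. Nothing measured here explains that gap. From the compounds shown here alone, whether an amine or a carboxylic acid on this ring would sit with compound 4 or with compound 1 remains open.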